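From chloro-methoxy back to a dimethylphenyl group

This account rests on a few compounds, and the source may have more. Where it says the series, first, only, none or still open, it means among the compounds named here.

Compound 1 `Cc1ccc(C)c(-c2nc(CN3CCC(C(=O)NCCCN4C[C@H](C)C[C@H](C)C4)CC3)c(C)o2)c1` gives 0.5 h
Compound 2 `COc1cccc(Cl)c1-c1nc(CN2CCC(C(=O)NCCCN3C[C@H](C)C[C@H](C)C3)CC2)c(C)o1` gives 0.055 h

Among the measured compounds shown here, in an ADME assay on microsomes from liver (Rattus norvegicus) for metabolic stability, read by LC-MS, using NADPH, at 37 degrees C (on this read-out lower numbers stand for a shorter-lived compound and higher numbers for a longer-lived compound), compound 2 stands lowest of the two, at 0.055 h, and compound 1 is its only neighbour. Compound 3 `Cc1cccc(C)c1-c1nc(CN2CCC(C(=O)NCCCN3C[C@H](C)C[C@H](C)C3)CC2)c(C)o1` differs from compound 2 in one place, (2,6-dimethylphenyl in place of 2-chloro-6-methoxyphenyl on an aromatic carbon), on an aromatic carbon of the shared core. For the measured compounds named here, one measured step bears on this change: a 9.1-fold lower number from compound 1 to compound 2 (0.96 log units; beyond the scatter), which brought in the same 2-chloro-6-methoxyphenyl in place of 2,5-dimethylphenyl. Going by the values given here, compound 3 also carries a dimethylphenyl, so a rise of similar size is expected in this assay, though no measured compound yet carries 2,6-dimethylphenyl and one step is thin support. The expected change is a 7.3-fold higher number from compound 2 to compound 3 (0.86 log units; beyond the scatter) in this direction. Compound 3 is estimated at 0.4 h, with an expected range from 0.15 h to 1 h.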

Compound 3, half-life: 0.0517 h
Compound 3: the middle estimate sits 7.7-fold (0.89 log units) above what was measured; the measured number lies below the stated range.
By their numbers in this assay, from the lowest: compounds 3 and 2 (each within the scatter of the next); then compound 1.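

In this assay this result shows that carrying a dimethylphenyl group is not enough on its own for a longer half-life. Putting 2,6-dimethylphenyl in place of 2-chloro-6-methoxyphenyl gives a 1.1-fold lower number from compound 2 to compound 3 (0.03 log units; within the scatter), so these two groups cannot be told apart on this read-out at this aromatic carbon. Putting 2,6-dimethylphenyl in place of 2,5-dimethylphenyl gives a 9.7-fold lower number from compound 1 to compound 3 (0.99 log units; beyond the scatter), so among these three compounds the number follows the arrangement of the groups on the phenyl ring more closely than the choice between methyl and the chloro-methoxy pair.

Nothing shown here accounts for the gap between the two dimethylphenyl groups. From the compounds shown here alone, it also remains open whether a plain phenyl or a 2,6-difluorophenyl at this carbon would sit with compound 3 or with compound 1.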